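A few compounds are considered here, and "the series" means these few. Any claim that something is new, unique, unknown or untested is made for them only; others in the source may bear on it.

Measured compounds:
- Compound 1 `O=S(=O)(NCCCCCCNCc1ccc(Br)cc1)c1ccc(C(F)(F)F)cc1` gives 3830 nM in a functional assay on MIA PaCa-2 cells (Homo sapiens) for inhibition, read by MTT assay, with a stated time of 72 h; on this read-out lower numbers stand for stronger inhibition of growth and higher numbers for weaker inhibition of growth.
- Compound 2 `CN(CCCNS(=O)(=O)c1cc(C(F)(F)F)cc(C(F)(F)F)c1)Cc1ccccc1` gives 33000 nM.
- Compound 3 `O=S(=O)(NCCCNCc1ccc(Br)cc1)c1cc(C(F)(F)F)cc(C(F)(F)F)c1` gives 2300 nM.

Compound 1 holds the second highest of the three numbers. Its nearest neighbour is compound 3, whose value sits within the scatter of that of compound 1, so no order between the two can be stated; compound 2 lies furthest away, beyond the scatter, at the weaker end.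

Compound 4 `O=S(=O)(NCCCCCCNCc1ccc(Br)cc1)c1ccc(Cl)cc1` differs from compound 1 in one place: chloro in place of trifluoromethyl on an aromatic carbon. Within the data shown here, the only measured step, a 14-fold lower number from compound 2 to compound 3 (1.16 log units; beyond the scatter), concerns the amine end of the chain and leaves the sulfonyl-bearing ring untouched, so it says nothing about the present change. Among the measured compounds shown here, no measured pair compares a chloro with a trifluoromethyl at this position. Without any bearing step, the expected step of a 1.3-fold higher number from compound 1 to compound 4 (0.12 log units; within the scatter) is none beyond the scatter. Compound 4 is therefore estimated at 5000 nM, with a range of 2000 nM to 13000 nM.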

Compound 4, concentration for 50% growth inhibition: 5900 nM
For compound 4 the middle estimate is 1.2-fold (0.07 log units) below the measured one, and the stated range covers the measured number.
By their numbers in this assay, from the lowest: compounds 3, 1 and 4 (each within the scatter of the next, the first and the last beyond it); then compound 2.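

In this assay, among these compounds, the change to chloro in place of trifluoromethyl gives a 1.5-fold higher number from compound 1 to compound 4 (0.19 log units; within the scatter) and is the first measured step on the sulfonyl-bearing ring, since the earlier step concerned only the amine end of the chain. At this aromatic carbon, para to a large group, one chlorine atom thus stands in for the four heavy atoms of trifluoromethyl with no difference that can be told from the scatter, and no order between the two compounds can be stated. No measured property of these groups is available to bear on this result.

From the compounds shown here alone, whether a nitrile, a methoxy group or a plain hydrogen at this carbon would also stay within the scatter remains open. So does the effect of a longer or shorter chain on the core of compound 1, with the ring and the amine end held fixed.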